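Removing the Fluoro Group From Compound 1

The source may hold more compounds than are shown below. What is called first, only, known or untested is meant among the compounds shown, and "the series" means these compounds.

Compound 1 `Nc1cccc(/C=C2\SC(=O)N(Cc3cccc(F)c3)C2=O)c1` is recorded in a functional assay on FM3A cells (Mus musculus) for cytotoxicity, read by cell counting, with a stated time of 2 days (a higher number here means a weaker inhibitor, a lower number a stronger inhibitor), only as a limit of the assay, > 250000 nM. Its close relative compound 2 `Nc1ccc(/C=C2\SC(=O)N(Cc3cccc(F)c3)C2=O)cc1` gives 121000 nM in this assay, and the step of an at least 2.0-fold lower number from compound 1 to compound 2 (0.31 log units; beyond the scatter) concerns the position of the amino group, not the fluoro. Compound 3 `C=C(Br)C(=O)Nc1ccc(/C=C2\SC(=O)N(CC)C2=O)cc1`, built on the same core, gives 2300 nM. Compound 4 `Nc1cccc(/C=C2\SC(=O)N(Cc3ccccc3)C2=O)c1` differs from compound 1 in one place (hydrogen in place of fluoro on an aromatic carbon). Among the compounds with values here, no measured pair shows what hydrogen in place of fluoro does on this core, so no step beyond the scatter is expected, a step that the limit leaves unreadable from compound 1 to compound 4. Compound 4 is therefore estimated at 300000 nM, within a range from 120000 nM to 1000000 nM, and is expected most likely to be reported again only as a limit.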

Compound 4, half-maximal inhibitory concentration: > 250000 nM
Compound 4 ended at the assay's limit; the forecaster's own chance of this, stated with the estimate: 70%; the middle value is on the limit's open side.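

No step can be read from compound 1 to compound 4, because both are recorded only as a limit of the assay: the limit of > 250000 nM in this assay, at which 2 of the 4 values shown sit. From the compounds shown here alone, what hydrogen in place of fluoro does to potency on the shared core stays open.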